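The source may report more compounds than this note shows. Statements on the series, on what has been measured and on what is new or still open speak of the compounds shown alone.

Compound 1 `CCN(c1ccc(C#N)c(Cl)c1)c1cc(-c2cccs2)ccc1C`: "not determined" (no result reported) in a functional assay on VCaP cells (Homo sapiens) for antiproliferative activity, read by CCK-8 assay, with a stated time of 6 days; a lower number here means a stronger inhibitor, a higher number a weaker inhibitor
Compound 2 `CCN(c1ccc(C#N)c(Cl)c1)c1cc(-c2cncnc2)ccc1C`: 3920 nM
Compound 3 `CCN(c1ccc(C#N)c(Cl)c1)c1cc(-c2cn[nH]c2)ccc1C`: "not determined" (no result reported) in this assay

Three compounds share one core and differ only in the aromatic group that hangs from it. Of the three, only compound 2 carries a number in this assay, and that number, 3920 nM, marks it as a weak inhibitor. In this assay compound 1 gives "not determined" (no result reported) and compound 3 gives "not determined" (no result reported), so nothing can be said about how their five-membered rings compare with the six-membered ring of compound 2.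

Compound 3 therefore stands without a number of its own, and the step to compound 4 `CCN(c1ccc(C#N)c(Cl)c1)c1cc(-c2c[nH]nc2C)ccc1C` starts from an unknown point. The change is methyl in place of hydrogen on an aromatic carbon. Going by the values given here, with no measured pair showing what this kind of change does, and with compound 3 itself unmeasured, no step beyond the usual scatter is expected in either direction in this assay; the only anchor is the weak activity of compound 2.

On that basis compound 4 is expected to give about 3500 nM in this assay, with a range from 800 nM to 15000 nM.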

Compound 4, half-maximal inhibitory concentration: 3190 nM
For compound 4 the middle estimate is 1.1-fold (0.04 log units) above the measured one, within the range that was stated.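

In this assay, going by these compounds alone, putting 3-methyl-1H-pyrazol-4-yl in place of pyrimidin-5-yl on the shared core gives a 1.2-fold lower number from compound 2 to compound 4 (0.09 log units; within the scatter) and so provides the first readable comparison in this set: at this place on the core, the two groups cannot be told apart. Going by these compounds, the step from compound 3 to compound 4 cannot be read, as compound 3 has no number, so what the methyl on the aromatic carbon next to the ring nitrogen does by itself remains unknown. No measurement is available that offers a reason for the result.

The compounds shown leave open whether another group on that same carbon of the 1H-pyrazol-4-yl ring, such as an ethyl chain, an amine or a carboxylic acid, would move the number beyond the scatter. Within the data shown here, they also leave open whether any aromatic group at this place on the core can give a markedly stronger inhibitor than compound 2 and compound 4, since these are the only two compounds here with numbers.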